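The source may hold more compounds than are shown below. What is called first, only, known or untested is meant among the compounds shown, and "the series" means these compounds.

Measured so far in a physicochemical assay for solubility, at pH 7.4; on this read-out lower numbers stand for lower solubility and higher numbers for higher solubility 
- Compound 1 `O=C(NCc1ccc(-c2noc(C3CCCCCC3)n2)cc1)[C@H]1NCC[C@@H]1O` gives > 50 ug/mL as a limit of the assay, not a number
- Compound 2 `CCCCCCCc1nc(-c2ccc([C@@H](NC(=O)[C@H]3NCC[C@@H]3O)C(C)C)cc2)no1` gives 3 ug/mL 
- Compound 3 `CCCCCCCc1cnc(-c2ccc(CNC(=O)[C@H]3NCC[C@@H]3O)cc2)s1` gives 4.2 ug/mL 

Only compound 2 and compound 3 carry numbers, and these lie within the scatter of each other, so no order can be read between them. Compound 1 sits at a limit (> 50 ug/mL) and has no number to compare.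

Compound 4 `CCCCCCCc1nc(-c2ccc([C@H](C)NC(=O)[C@H]3NCC[C@@H]3O)cc2)no1` is the next to be read. It differs from compound 2 in one place: methyl in place of isopropyl on a saturated chain carbon bound to an amide-type nitrogen and an aromatic carbon. For the measured compounds named here, no two measured compounds differ in one place only, so no measured step speaks to this change. The expectation rests on the two numbers alone: compound 2 at 3 ug/mL and compound 3 at 4.2 ug/mL sit close together, and the estimate stays near them. In this assay a small rise is expected, within the scatter or close to its edge. The expected size is a 1.7-fold higher number from compound 2 to compound 4 (0.22 log units; within the scatter) as estimated here. For compound 4 the estimated value is 5 ug/mL with an expected range from 2 ug/mL to 14 ug/mL on this read-out.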

Compound 4, solubility: 27 ug/mL
The estimate for compound 4 lay 5.4-fold (0.73 log units) below the measured number; the measured number lies above the stated range.
By their numbers in this assay, from the lowest: compounds 2 and 3 (each within the scatter of the next); then compound 4. At a limit, above all of these: compound 1.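

In this assay, the saturated chain carbon bound to an amide-type nitrogen and an aromatic carbon proves to be a place where the read-out responds: methyl in place of isopropyl there goes with a 9.0-fold higher number from compound 2 to compound 4 (0.95 log units; beyond the scatter). For the compounds shown here, the earlier compounds offered no pair differing in one place, so this is the first change whose size can be tied to a single group, and here the loss of 3 heavy atoms for 1 is enough to carry the step beyond the scatter. Both ends of this step are numbers, while compound 1 alone stands at a limit: the limit of > 50 ug/mL in this assay, at which 1 of the 4 values shown sits.

Going by these compounds, a single step at one place gives no trend with group size, so it remains open whether an ethyl group at this carbon would fall on a smooth course between methyl and isopropyl, or whether an aminomethyl or hydroxymethyl group would read differently from either. On these data alone, it also remains open whether the same exchange of isopropyl for methyl gives a step of similar size on the core of compound 3.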